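An isopropyl on the amide-type nitrogen of compound 1

The source may report more compounds than this note shows. Statements on the series, on what has been measured and on what is new or still open speak of the compounds shown alone.

Measured in an ADME assay on CEM-SS cells (Homo sapiens) for cytotoxicity, read by XTT assay; on this read-out lower numbers stand for higher toxicity in this test and higher numbers for lower toxicity in this test:
- compound 1 `O=C(NO)c1cc2ccn(Cc3ccc(F)cc3)c2cn1`: 159000 nM
- compound 2 `O=C(NO)c1cc2ccn(Cc3ccc(Cl)s3)c2cn1`: > 10000 nM, which is a limit

Among the measured compounds shown here, compound 1 holds the only true number so far. Compound 3 `CC(C)N(O)C(=O)c1cc2ccn(Cc3ccc(F)cc3)c2cn1` differs from it at one place: isopropyl in place of hydrogen on an amide-type nitrogen. For the measured compounds named here, the one measured step, a step that the limit leaves unreadable from compound 1 to compound 2, concerns a different place and gives no size, so it offers no guide to this change. With no measured guide, no shift beyond the usual scatter is expected in this assay, and the expected step is a 1.2-fold lower number from compound 1 to compound 3 (0.09 log units; within the scatter). The estimated value for compound 3 is 130000 nM, with an expected range of 30000 nM to 320000 nM.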

Compound 3, half-maximal cytotoxic concentration: 36000 nM
The estimate for compound 3 lay 3.6-fold (0.56 log units) above the measured number, within the range that was stated.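

Putting isopropyl in place of hydrogen on the amide-type nitrogen gives a 4.4-fold lower number from compound 1 to compound 3 (0.65 log units; beyond the scatter) in this assay and so moves toward higher toxicity in this test. Among the compounds shown here, this is the first step of readable size, and it shows that the read-out responds to a change at this nitrogen. Nothing shown here explains the shift. Going by these compounds, whether methyl or a longer chain on this nitrogen would give a smaller or larger step remains open. So does whether isopropyl would act alike on compound 2.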